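Extending the pyrazole nitrogen substituent toward benzyl

The source may hold more compounds than are shown below. What is called first, only, known or untested is meant among the compounds shown, and "the series" means these compounds.

Measured compounds:
compound 1, `CCOC(=O)c1cc(-c2cccc(OC(=O)NC3CCCCC3)c2)n(C)n1`: 303 nM
compound 2, `CCOC(=O)c1cc(-c2cccc(OC(=O)NC3CCCCC3)c2)n(CC)n1`: 101 nM

Among the measured compounds shown here, in an assay on isolated protein for inhibition of Fatty-acid amide hydrolase 1 (Homo sapiens), read by fluorescence, with a stated time of 30 min (on this read-out lower numbers stand for stronger inhibition and higher numbers for weaker inhibition), compound 2 gives 101 nM and stands at the lower of the two measured values; its only neighbour is compound 1, which gives 303 nM in this assay. For the measured compounds named here, the one measured step, a 3.0-fold lower number from compound 1 to compound 2 (0.48 log units; beyond the scatter), is the only comparison available, and it concerns the same position that changes next.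

Compound 3, `CCOC(=O)c1cc(-c2cccc(OC(=O)NC3CCCCC3)c2)n(Cc2ccccc2)n1`, differs from compound 2 by phenyl in place of methyl on a saturated chain carbon bound to an aromatic nitrogen. The step from compound 1 to compound 2 bears on this change in that it also enlarged the group at that position, and it produced a modest gain. Whether a much larger group at the same place continues that trend cannot be read from a single step, so the expectation is cautious: a small further lowering of the number, or no step beyond the scatter. The expected step in this assay is a 1.4-fold lower number from compound 2 to compound 3 (0.16 log units; within the scatter). Compound 3 is therefore estimated at 70 nM, with a range from 20 nM to 300 nM.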

Compound 3, half-maximal inhibitory concentration: 70 nM
Estimate against measurement, compound 3: no gap at the digits printed; measured number inside the range.
By their numbers in this assay, from the lowest: compounds 3 and 2 (each within the scatter of the next); then compound 1.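

In this assay the saturated chain carbon bound to an aromatic nitrogen carries a phenyl group without any loss, and going from ethyl to benzyl gives a 1.4-fold lower number from compound 2 to compound 3 (0.16 log units; within the scatter), so this much larger group does not separate the two compounds. Against the smallest group shown at this place, the change gives a 4.3-fold lower number from compound 1 to compound 3 (0.64 log units; beyond the scatter), and so compound 3 keeps the gain beyond the scatter that compound 2 already showed over compound 1, while the trend of improvement with each enlargement seen in the first step does not clearly continue. No measurement shown here bears on why the added ring leaves the number within the scatter of compound 2.

The compounds shown leave open whether a substituent on the new ring, such as a fluorine or a methoxy group, or a longer chain between the ring and the nitrogen, such as phenethyl, would move the number beyond the scatter. They also leave open whether a benzyl group would hold its place in this assay if the ethyl ester gave way to a carboxylic acid or an amide.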